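Methyl for Hydroxy Next to the Ring Nitrogen

A few compounds are considered here, and "the series" means these few. Any claim that something is new, unique, unknown or untested is made for them only; others in the source may bear on it.

Measured compounds:
compound 1, `CC(C)(C)c1ccc(NC(=O)c2ccc(-c3ncccc3NS(C)(=O)=O)cc2)cc1`, 35 nM
compound 2, `O=C(Nc1ccc(C(F)(F)F)cc1)c1ccc(-c2ncccc2C(F)(F)F)nc1O`, 764 nM

In a functional assay for antagonist activity at transient receptor potential cation channel subfamily V member 1 (Rattus norvegicus) (on this read-out higher numbers stand for weaker inhibition and lower numbers for stronger inhibition), compound 1 gives 35 nM, while compound 2 gives 764 nM, the higher of the two numbers, and the gap between them lies beyond the usual scatter. Compound 3, `Cc1nc(-c2ncccc2C(F)(F)F)ccc1C(=O)Nc1ccc(C(F)(F)F)cc1`, has not yet been measured in this assay. It differs from compound 2 in one place: methyl in place of hydroxy on an aromatic carbon, where the hydroxy that leaves and the methyl that enters are each a single heavy atom. Among the measured compounds shown here, no measured pair shows the same change, so the size of the step is uncertain. The account expects a moderate step toward a lower number, beyond the scatter, a 5.1-fold lower number from compound 2 to compound 3 (0.71 log units; beyond the scatter). For compound 3 the estimated value in this assay is 150 nM, within a range from 40 nM to 600 nM.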

Compound 3, half-maximal inhibitory concentration: 263 nM
Compound 3: the middle estimate sits 1.8-fold (0.24 log units) below what was measured, within the range that was stated.
By their numbers in this assay, from the lowest: compound 1; then compound 3; then compound 2.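

Among the compounds shown here, the exchange of hydroxy for methyl next to the ring nitrogen gives a 2.9-fold lower number from compound 2 to compound 3 (0.46 log units; beyond the scatter) in this assay, the first single-place comparison at this position. Methyl carries no hydrogen-bond donor or acceptor, so the pair shows that inhibition at this position does not depend on keeping the hydroxy, and that the number moves modestly when it is replaced. Nothing measured here accounts for the direction or size of this step.

The compounds shown leave open whether the step reflects the arrival of methyl or the departure of hydroxy, as only these two groups are compared at this position. Going by these compounds, how an amine, a methoxy group or an ethyl group would fare there remains unknown, as does whether the same change would carry over to the core of compound 1.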